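This account rests on a few compounds, and the source may have more. Where it says the series, first, only, none or still open, it means among the compounds named here.

Compound 1 `N/C(=N\NC(=S)N1CCSCC1)c1ccccn1` is one of three related compounds tested in a functional assay on MCF7 cells (Homo sapiens) for cytotoxicity, read by MTT assay, with a stated time of 72 h, tested at 100 uM (a lower number here means less inhibition of growth, a higher number more inhibition of growth at the concentration tested), where compound 1 gives 72.4%. Compound 2 `N/C(=N\NC(=S)N1CCCCCC1)c1ccccn1` gives 84% in this assay, a number beyond the scatter above that of compound 1, while compound 3 `Cc1cccc(/C(N)=N/NC(=S)N2CCN(c3ccccn3)CC2)n1` gives 49.8%, beyond the scatter below it, so compound 1 stands second of the three. Compound 4 `N/C(=N\NC(=S)N1CCCCC1)c1ccccn1` has not been measured. It differs from compound 1 in one place: piperidin-1-yl in place of thiomorpholin-4-yl on a thiocarbonyl carbon. No measured pair differs in exactly this way, so the step cannot be read from the numbers shown. Compound 1 is expected to give a number 5.6 percentage points higher from compound 1 to compound 4 (within the scatter), a small step upward that may lie within the scatter. Compound 4 is therefore estimated at 78%, ranging from 66% to 90%.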

Compound 4, percent growth inhibition at one concentration: 77.7%
Compound 4: the middle estimate sits 0.3 percentage points above what was measured; low and high end bracket the measured number.
By their numbers in this assay, from the lowest: compound 3; then compounds 1, 4 and 2 (each within the scatter of the next, the first and the last beyond it).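

In this assay the change to piperidin-1-yl in place of thiomorpholin-4-yl on a thiocarbonyl carbon gives a number 5.3 percentage points higher from compound 1 to compound 4 (within the scatter) and so shows that, in this pair, growth inhibition at the concentration tested does not depend on the ring sulfur. Both six-membered rings serve about equally at this position. No evidence is at hand that would account for this result.

As far as these compounds go, whether morpholin-4-yl or an open-chain diethylamino group would serve equally well at this place stays open.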